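This account rests on a few compounds, and the source may have more. Where it says the series, first, only, none or still open, it means among the compounds named here.

Measured so far:
compound 1, `CC(C(=O)NCc1ccc(C(F)(F)F)cc1N1CCC(C(F)(F)F)CC1)c1ccc(NS(C)(=O)=O)c(F)c1`, gives 0.4 nM
compound 2, `CCCCCCSc1cc(C(F)(F)F)ccc1CNC(=O)C(C)c1ccc(NS(C)(=O)=O)c(F)c1`, gives 1.8 nM

In an assay on CHO cells for antagonist activity at transient receptor potential cation channel subfamily V member 1 (Homo sapiens), read by FLIPR (on this read-out higher numbers stand for weaker inhibition and lower numbers for stronger inhibition), compound 2 has the higher of the two numbers; its nearest neighbour is compound 1. Going by the values given here, the only measured step is a 4.5-fold higher number from compound 1 to compound 2 (0.65 log units; beyond the scatter), where hexylsulfanyl replaced 4-(trifluoromethyl)piperidin-1-yl on an aromatic carbon. Compound 3, `COc1ccc(-c2cc(C(F)(F)F)ccc2CNC(=O)C(C)c2ccc(NS(C)(=O)=O)c(F)c2)cc1OC`, differs from compound 2 by 3,4-dimethoxyphenyl in place of hexylsulfanyl on an aromatic carbon. Since the step that swapped a ring for a chain raised the number, restoring a ring at the same aromatic carbon is expected to lower it modestly, a 1.8-fold lower number from compound 2 to compound 3 (0.26 log units; within the scatter). Compound 3 is therefore estimated at 1 nM, with a range from 0.3 nM to 4 nM.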

Compound 3, inhibition constant: 8.6 nM
The estimate for compound 3 lay 8.6-fold (0.93 log units) below the measured number; the whole stated range lies below it.
By their numbers in this assay, from the lowest: compound 1; then compound 2; then compound 3.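

Putting an aromatic ring on this carbon does not recover what the chain lost: in this assay, 3,4-dimethoxyphenyl gives the highest number of the three groups (a 4.8-fold higher number from compound 2 to compound 3 (0.68 log units; beyond the scatter)) and (a 22-fold higher number from compound 1 to compound 3 (1.33 log units; beyond the scatter)). Having a ring is therefore not enough on its own, since these two ring-bearing groups sit on either side of the hexylsulfanyl chain. No supporting data bear on this result. The compounds shown leave open whether a plain phenyl would behave like 3,4-dimethoxyphenyl. They also leave open how a shorter butylsulfanyl chain or an unsubstituted piperidine would compare.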